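The compounds below may be only part of what the source reports. "The series", "measured", "known", "first", "only" and "open" are said of these compounds alone.

Measured in an ADME assay on MDBK cells (Bos taurus) for cytotoxicity, read by MTT assay, with a stated time of 96 h; a higher number here means that more compound is tolerated, a lower number that less compound is tolerated:
- compound 1 `COc1ccc(-c2nc3cc(/C(C)=N/NC(N)=O)ccc3n2C2CCCCC2)c(OC)c1`: 36000 nM
- compound 2 `C/C(=N\NC(N)=O)c1ccc2c(c1)nc(-c1ccoc1)n2C1CCCCC1`: > 100000 nM (a limit of the assay)

Among the measured compounds shown here, compound 1 gives the only actual number so far, the other result being a limit. Compound 3 `COc1ccc(-c2nc3cc(/C(C)=N/NC(N)=S)ccc3n2C2CCCCC2)c(OC)c1` keeps the core of compound 1 and changes only the carbamoyl group on an amine nitrogen: a group of 3 heavy atoms (1 carbon, 1 nitrogen, 1 sulfur; no ring) in place of a group of 3 heavy atoms (1 carbon, 1 nitrogen, 1 oxygen; no ring), on an amine nitrogen.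

For the measured compounds named here, the one measured step, an at least 2.7-fold higher number from compound 1 to compound 2 (0.44 log units; beyond the scatter), is furan-3-yl in place of 2,4-dimethoxyphenyl on an aromatic carbon. It concerns a different group and shows only that this assay can move beyond the scatter within this series. Going by the values given here, no measured step covers the carbamoyl exchange, so no step beyond the scatter is expected, with a slight lean towards a lower number. The estimated change is a 1.4-fold lower number from compound 1 to compound 3 (0.16 log units; within the scatter). For compound 3 the estimated value is 25000 nM, with an expected range of 8000 nM to 80000 nM.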

Compound 3, half-maximal cytotoxic concentration: > 100000 nM
Compound 3 gave a limit, no number (the forecaster's own chance of this, stated with the estimate: 12%); at least 4.0-fold (0.60 log units) between middle value and limit.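

In this assay, the sulfur-bearing group in place of carbamoyl on an amine nitrogen gives an at least 2.7-fold higher number from compound 1 to compound 3 (0.44 log units; beyond the scatter), so this site, and not only the aromatic carbon changed in compound 2, can move the result beyond the scatter. A change of a single atom in this group, oxygen to sulfur, is enough for this, with the 2,4-dimethoxyphenyl group kept. The result for compound 3 is a limit of the assay and not a number, so the step sets only a lower bound on the size of the shift, and its full size cannot be read because of that limit: the limit of > 100000 nM in this assay, at which 2 of the 3 values shown sit.

Open, going by these compounds, is whether the same exchange would also give a shift with furan-3-yl in place of 2,4-dimethoxyphenyl. Also open, on these data alone, is how an acetyl group or a methyl group on this amine nitrogen would read in this assay.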